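The source may hold more compounds than are shown below. What is called first, only, known or untested is meant among the compounds shown, and "the series" means these compounds.

The series shares a core carrying a methylpyrazole, and the three compounds already measured differ in the group attached at the other end of that core. Compound 1 `CC(Nc1ncnc2ncc(-c3cnn(C)c3)cc12)c1ccncc1` gave only a limit in a functional assay on MDA-MB-231 cells (Homo sapiens) for antiproliferative activity, read by MTT assay, with a stated time of 72 h (on this read-out lower numbers stand for stronger inhibition and higher numbers for weaker inhibition), > 100000 nM, and that limit of > 100000 nM in this assay, at which 1 of the 3 values shown sits, is the sole point of that kind among the values shown. Compound 2 `Cn1cc(-c2ccc3ncnc(Oc4ccc5ncccc5c4)c3c2)cn1` gives 16500 nM in this assay. Compound 3 `C#Cc1cccc(Nc2ncnc3ccc(-c4cnn(C)c4)cc23)c1` gives 16900 nM in this assay; it is one of the two real numbers obtained, and its gap to compound 2 is within the usual scatter, so no order between the two can be claimed.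

Compound 4 `Cn1cc(-c2ccc3ncnc(Nc4ccc(F)c(Cl)c4)c3c2)cn1` has not yet been measured in this assay. It differs from compound 3 in a single place: 3-chloro-4-fluorophenyl in place of 3-ethynylphenyl on a nitrogen on an aromatic ring. The group that leaves and the group that enters have the same heavy-atom count and neither carries a hydrogen-bond donor or acceptor. For the measured compounds named here, no measured pair in the set isolates such a swap, so there is nothing to anchor a directional expectation, and the step is expected to stay within the scatter, a 1.1-fold lower number from compound 3 to compound 4 (0.05 log units; within the scatter). Compound 4 is therefore estimated at 15000 nM in this assay, with a likely range from 4000 nM to 60000 nM.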

Compound 4, half-maximal inhibitory concentration: 62700 nM
Compound 4: middle estimate off by 4.2-fold (0.62 log units), on the low side, outside the stated range (above it).
By their numbers in this assay, from the lowest: compounds 2 and 3 (each within the scatter of the next); then compound 4. At a limit, above all of these: compound 1.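

In this assay, for the compounds shown here, placing 3-chloro-4-fluorophenyl in place of 3-ethynylphenyl on a nitrogen on an aromatic ring gives a 3.7-fold higher number from compound 3 to compound 4 (0.57 log units; beyond the scatter), the first step that isolates a single change, and it goes towards weaker inhibition. This place on the shared core therefore responds to the identity of its group even when the heavy-atom count stays the same, both groups keep one six-membered aromatic ring of carbon only, and neither carries a hydrogen-bond donor or acceptor; what differs is that a triple bond leaves while a chlorine and a fluorine enter. Nothing in the data at hand accounts for the size or direction of this step.

The swap removes the triple bond and brings in both halogens at once, so the compounds shown cannot say which of these changes goes with the higher number. A plain phenyl, a phenyl carrying only a chlorine or only a fluorine, or a phenyl carrying an amine on the same nitrogen would be needed to separate these contributions and to show how far the number at this place can move.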